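A chloro swap on the methyl-bearing carbon

The source may report more compounds than this note shows. Statements on the series, on what has been measured and on what is new or still open speak of the compounds shown alone.

In a functional assay on MDA-MB-468 cells (Homo sapiens) for inhibition (on this read-out higher numbers stand for weaker inhibition and lower numbers for stronger inhibition), compound 1 (`O=S(=O)(O)Nc1ccc(-c2nc3ccccc3s2)cc1`) gives 7500 nM while compound 2 (`Cc1cc(-c2nc3ccccc3s2)ccc1NS(=O)(=O)O`) gives 720 nM as the lower of the two numbers, which makes it the stronger inhibitor of this pair. Among the measured compounds shown here, the one measured step is a 10-fold lower number from compound 1 to compound 2 (1.02 log units; beyond the scatter) and it is large, with methyl in place of hydrogen on an aromatic carbon.

Compound 3 (`O=S(=O)(O)Nc1ccc(-c2nc3ccccc3s2)cc1Cl`) has chloro in place of methyl on that same aromatic carbon, ortho to a sulfoamino group (chloro in place of methyl on an aromatic carbon). For the measured compounds named here, no measurement yet shows a chloro group on the shared core, so the evidence is thin. Compound 3 keeps a group other than hydrogen on that carbon, so it is expected to stay nearer compound 2 than compound 1, given the size of a 10-fold lower number from compound 1 to compound 2 (1.02 log units; beyond the scatter) in that direction. Only a slight move towards a higher number is expected, within the scatter, and the estimated change is a 1.3-fold higher number from compound 2 to compound 3 (0.10 log units; within the scatter) at most as a rough guide. The expected value for compound 3 in this assay is 900 nM with a range from 250 nM to 3000 nM expected.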

Compound 3, half-maximal inhibitory concentration: 9000 nM
For compound 3 the middle estimate is 10-fold (1.00 log units) below the measured one, outside the stated range (above it).
By their numbers in this assay, from the lowest: compound 2; then compounds 1 and 3 (each within the scatter of the next).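

The step of a 13-fold higher number from compound 2 to compound 3 (1.10 log units; beyond the scatter) shows that, in this assay, the low number of compound 2 depends on which group sits on this carbon: a group other than hydrogen there is not enough, since chloro does not keep what methyl gave. The step of a 1.2-fold higher number from compound 1 to compound 3 (0.08 log units; within the scatter) puts chloro within the scatter of hydrogen at this position, so among the three compounds only methyl stands apart, and compound 3 goes against any reading in which substitution on this carbon alone lowers the number. No measurement at hand offers an explanation of why methyl and chloro part so sharply here.

The compounds shown leave open whether the low number belongs to methyl alone or extends to other groups on this carbon, such as ethyl, methoxy or an amine. They also leave open whether the wide gap between methyl and chloro would persist if a carboxylic acid stood in place of the sulfoamino group.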